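The source may report more compounds than this note shows. Statements on the series, on what has been measured and on what is new or still open speak of the compounds shown alone.

Measured in a functional assay on MCF-A cells (Homo sapiens) for cytotoxicity; a higher number here means a weaker inhibitor of growth, a lower number a stronger inhibitor of growth:
Compound 1 `CSc1ccc(C2=C(c3ccc(F)c(C)c3)C(=O)N3CCCC3C2)cc1`: 500 nM
Compound 2 `CSc1ccc(C2=C(c3ccc(O)cc3)C(=O)N3CCCC3C2)cc1`: > 100000 nM

Compound 2 gives > 100000 nM, which is a limit of this assay and not a number. It therefore marks the weak end of the two measured compounds, and no exact value is available as a starting point.

Compound 3 `CSc1ccc(C2=C(c3ccc(Br)cc3)C(=O)N3CCCC3C2)cc1` has bromo in place of hydroxy on an aromatic carbon, para to a large group. The same difference can be read as 4-hydroxyphenyl to 4-bromophenyl.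

For the measured compounds named here, only one measured step bears on this change: an at least 200-fold higher number from compound 1 to compound 2 (2.30 log units; beyond the scatter). That step introduced the 4-hydroxyphenyl group in place of 4-fluoro-3-methylphenyl, at the same place on the shared core. Compound 3 gives up the hydroxy group again, so much of that large loss is expected to be recovered, although bromo was not part of that step. Compound 1, which has no hydroxy group, gives 500 nM, and this value serves as the reference point.

A large step toward a lower number is therefore expected, and it is estimated as an at least 100-fold lower number from compound 2 to compound 3 (2.00 log units; beyond the scatter). Compound 3 is expected at about 1000 nM, with an estimated range from 150 nM to 10000 nM.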

Compound 3, concentration for 50% growth inhibition: 8000 nM
The estimate for compound 3 lay 8.0-fold (0.90 log units) below the measured number; the range from low to high includes it.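

In this assay, bromo in place of hydroxy on the aromatic carbon gives an at least 12-fold lower number from compound 2 to compound 3 (1.09 log units; beyond the scatter), so this position does not reject every group placed there, and the hydroxy compound is not simply the expected result of changing the 4-fluoro-3-methylphenyl group. The recovery is only partial, however, since 4-bromophenyl in place of 4-fluoro-3-methylphenyl still gives a 16-fold higher number from compound 1 to compound 3 (1.20 log units; beyond the scatter), which shows that removing the hydroxy group does not by itself restore the number seen with compound 1. Compound 2 gives > 100000 nM, which is a limit of this assay and not a number, so the step from it has a bound and no exact size: the limit of > 100000 nM in this assay, at which 1 of the 3 values shown sits.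

The compounds shown leave open whether the advantage of compound 1 over compound 3 belongs to the fluoro, to the methyl or to the two together, as the 4-fluoro-3-methylphenyl group differs from 4-bromophenyl in more than one substituent. They also leave open how a methoxy group, an amine or a carboxylic acid on that same aromatic carbon would read in this assay.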